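This account rests on a few compounds, and the source may have more. Where it says the series, first, only, none or still open, it means among the compounds named here.

Measured in a functional assay on DU-145 cells (Homo sapiens) for antiproliferative activity, read by propidium iodide staining, with a stated time of 96 h; a higher number here means a weaker inhibitor, a lower number a stronger inhibitor:
Compound 1 `CC(O)(COc1ccccc1C(F)(F)F)C(=O)Nc1cccc(S(F)(F)(F)(F)F)c1`: 52200 nM
Compound 2 `CC(O)(CS(=O)(=O)c1ccc(S(F)(F)(F)(F)F)cc1)C(=O)Nc1ccc(S(F)(F)(F)(F)F)cc1`: 28900 nM
Compound 3 `CC(O)(CS(=O)(=O)c1ccc(F)cc1)C(=O)Nc1ccc(S(F)(F)(F)(F)F)cc1`: 27700 nM

All three numbers lie within the scatter of one another, so compound 3, at 27700 nM, cannot be told apart from compound 1 or compound 2.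

Compound 4 `CC(O)(CS(=O)(=O)c1ccc(C(F)(F)F)cc1)C(=O)Nc1ccc(S(F)(F)(F)(F)F)cc1` differs from compound 3 in a single group: trifluoromethyl in place of fluoro on an aromatic carbon. This puts trifluoromethyl in place of fluoro on an aromatic carbon, para to a large group.

For the measured compounds named here, one measured step bears on this, as it changes the same aromatic carbon: a 1.0-fold lower number from compound 2 to compound 3 (0.02 log units; within the scatter). Exchanging the group there left the number unchanged within the scatter. A single step is thin evidence, but it gives no reason to expect a real shift at this carbon.

The expected size in this assay is a 1.0-fold higher number from compound 3 to compound 4 (0.00 log units; within the scatter), which means no expected change beyond the scatter, in either direction. For compound 4 the estimated value is 28000 nM, with an expected range from 14000 nM to 55000 nM.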

Compound 4, half-maximal inhibitory concentration: 29300 nM
For compound 4 the middle estimate is 1.0-fold (0.02 log units) below the measured one; measured number inside the range.
By their numbers in this assay, from the lowest: compounds 3, 2, 4 and 1 (each within the scatter of the next).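

In this assay, the exchange of 4-fluorophenyl for 4-(trifluoromethyl)phenyl gives a 1.1-fold higher number from compound 3 to compound 4 (0.02 log units; within the scatter) and so does not separate these two compounds. Trifluoromethyl also cannot be told apart from the larger group of 6 heavy atoms at the same aromatic carbon, with a 1.0-fold higher number from compound 2 to compound 4 (0.01 log units; within the scatter) as the step. For the compounds shown here, the earlier compounds offered only two groups at this carbon, whereas three groups of different sizes, para to a large group, now give numbers within the scatter of one another.

From the compounds shown here alone, all three groups contain fluorine, so it remains open whether an amine or a carboxylic acid on this carbon would shift the number beyond the scatter. No supporting evidence is available to explain why these three groups cannot be told apart.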